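This account rests on a few compounds, and the source may have more. Where it says the series, first, only, none or still open, it means among the compounds named here.

Working notes on the series in an ADME assay for permeability; on this read-out lower numbers stand for lower permeability and higher numbers for higher permeability. Compound 1 `CNC(=O)c1cc(C(=O)N[C@H]2[C@@H]3C[C@@H](O)C[C@@H]32)n([C@@H](C)c2cccc(Cl)c2)n1` gives 197 nm/s. Compound 2 `CNC(=O)c1cc(C(=O)N[C@H]2[C@@H]3C[C@@H](O)C[C@@H]32)n([C@@H](C)c2ccccc2)n1` gives 61 nm/s. Compound 3 `CNC(=O)c1cc(C(=O)NC(C)CO)n([C@@H](C)c2ccccc2)n1` gives 120 nm/s. Compound 2 holds the lowest of the three numbers, but only its gap to compound 1 lies beyond the scatter; its gap to compound 3 does not. The two measured steps read: a 3.2-fold lower number from compound 1 to compound 2 (0.51 log units; beyond the scatter), and a 2.0-fold higher number from compound 2 to compound 3 (0.29 log units; within the scatter).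

Compound 4 `CC[C@@H](c1ccccc1)n1nc(C(=O)NC)cc1C(=O)N[C@H]1[C@@H]2C[C@@H](O)C[C@@H]21` differs from compound 2 by methyl in place of hydrogen on a saturated chain carbon, two bonds along the chain from an aromatic carbon and an aromatic nitrogen. Within the data shown here, no measured step touches that chain carbon, so the precedent is indirect. The nearest one is at the aromatic ring, where a 3.2-fold lower number from compound 1 to compound 2 (0.51 log units; beyond the scatter) shows a modest fall when one heavy atom leaves; by loose analogy, the entry of one carbon in compound 4 is expected to move the number modestly upward, as a 1.5-fold higher number from compound 2 to compound 4 (0.17 log units; within the scatter), though a step within the scatter would not surprise. Compound 4 is therefore expected near 90 nm/s, with a range from 50 nm/s to 170 nm/s.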

Compound 4, apparent permeability: 120 nm/s
Beside the measured number, compound 4's estimate is 1.3-fold (0.12 log units) below it; the range from low to high includes it.
By their numbers in this assay, from the lowest: compounds 2, 3, 4 and 1 (each within the scatter of the next, the first and the last beyond it).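

In this assay this saturated chain carbon now has a measured step of its own: a 2.0-fold higher number from compound 2 to compound 4 (0.29 log units; within the scatter) for methyl in place of hydrogen, so this change at this position gives no difference that can be separated from the scatter. Compound 1 and compound 2 stand beyond the scatter of each other, yet a 1.6-fold lower number from compound 1 to compound 4 (0.22 log units; within the scatter) places compound 4, which carries no chloro, within the scatter of compound 1, although that step changes the aromatic ring substituent as well as the chain. No measurement given here accounts for either step.

As far as these compounds go, whether a longer chain such as propyl, or a hydroxymethyl group, on this carbon would give a step beyond the scatter remains open. Also open, from the compounds shown here alone, is whether the methyl change reads the same with chloro on the aromatic ring or on the open-chain amide of compound 3.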